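The source may report more compounds than this note shows. Statements on the series, on what has been measured and on what is new or still open speak of the compounds shown alone.

Within the data shown here, compound 1 `Cc1ccc(SCc2ccc(/C=C/C(=O)Nc3ccccc3N)cc2)cc1` stands highest of the two compounds measured so far. In a functional assay on A-375 cells (Homo sapiens) for inhibition, read by CCK-8 assay, with a stated time of 72 h, tested at 2 uM (a higher number here means more inhibition of growth at the concentration tested, a lower number less inhibition of growth), compound 1 gives 22.9%, while compound 2 `Nc1ccccc1NC(=O)c1ccc(CSc2ccc(Br)cc2)cc1` gives 4.35%, a gap beyond the usual scatter. Compound 3 `Nc1ccccc1NC(=O)/C=C/c1ccc(CSc2ccc(Cl)cc2)cc1` differs from compound 1 by a single change: chloro in place of methyl on an aromatic carbon. Among the measured compounds shown here, no pair of measured compounds shows this change on its own, so its direction is uncertain, and the step in this assay is expected to be small, within the scatter or close to it. Compound 3 is therefore estimated at 22%, with a range of 8% to 38%, an expected step of a number 0.9 percentage points lower from compound 1 to compound 3 (within the scatter).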

Compound 3, percent growth inhibition at one concentration: 13.4%
For compound 3 the middle estimate is 8.6 percentage points above the measured one; measured number inside the range.
By their numbers in this assay, from the lowest: compounds 2, 3 and 1 (each within the scatter of the next, the first and the last beyond it).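

Among these compounds, the first pair to isolate this change on the 4-substituted phenyl ring shows, in this assay, a number 9.5 percentage points lower from compound 1 to compound 3 (within the scatter) on going from 4-methylphenyl to 4-chlorophenyl. The position therefore accepts chloro in place of methyl without a step beyond the scatter, although both compounds remain modest at the concentration tested. No measurement available here bears on the reason for this result. Still open, going by these compounds, is how a methoxy group, an amine or a carboxylic acid at this position would read. On these data alone, whether the same change behaves alike on another core also remains open.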